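The source may report more compounds than this note shows. Statements on the series, on what has been measured and on what is new or still open speak of the compounds shown alone.

Measured compounds:
compound 1, `N=C(N)NCCC[C@H](NC(=O)[C@@H]1CCCN1C(=O)[C@@H](NC(=O)OCc1ccccc1)C1CCCCC1)C(=O)CF`, 1450 nM;
compound 2, `CC(C)[C@H](NC(=O)OCc1ccccc1)C(=O)N1CCCC[C@H]1C(=O)N[C@@H](CCCNC(=N)N)C(=O)CF`, 730 nM;
compound 3, `CC(C)[C@H](NC(=O)c1ccc(Br)cc1)C(=O)N1CCCC[C@H]1C(=O)N[C@@H](CCCNC(=N)N)C(=O)CF`, 460 nM.

All three were tested in a functional assay on OCI-Ly3 cells (Homo sapiens) for inhibition, read by CellTiter-Glo, with stated times of 48 h and 96 h; a higher number here means a weaker inhibitor of growth, a lower number a stronger inhibitor of growth. Compound 1 has the highest number of the three; compound 2 sits nearest to it, a gap that lies within the scatter, while compound 3 lies furthest from it, a gap that goes beyond the scatter. Compound 1 and compound 2 share little that can be set side by side: the difference between the two cores is not broken down here.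

Within the series of compound 2, one change is measured. From compound 2 to compound 3 the change is 4-bromophenyl in place of benzyloxy on a carbonyl carbon, and it gives a 1.6-fold lower number from compound 2 to compound 3 (0.20 log units; within the scatter).

Compound 4, `N=C(N)NCCC[C@H](NC(=O)[C@@H]1CCCN1C(=O)[C@@H](NC(=O)c1ccc(Br)cc1)C1CCCCC1)C(=O)CF`, has not yet been tested in this assay . It is related to compound 1 by 4-bromophenyl in place of benzyloxy on a carbonyl carbon. The place of this change is described in the same words as for the step from compound 2 to compound 3, so it is the same change, made on the core of compound 1 instead of the core of compound 2.

On that footing, compound 4 is expected to move from compound 1 by a 1.6-fold lower number from compound 1 to compound 4 (0.21 log units; within the scatter), a step sized after the measured one from compound 2 to compound 3, which stayed within the scatter. For compound 4 the estimated value is therefore 900 nM, with an expected range from 450 nM to 1800 nM. This expectation rests on a single measured pair, so a change made on a different core may not carry over in full.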

Compound 4, concentration for 50% growth inhibition: 130 nM
The estimate for compound 4 lay 6.9-fold (0.84 log units) above the measured number; measured number below the stated range.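

In this assay, 4-bromophenyl in place of benzyloxy on a carbonyl carbon gives an 11-fold lower number from compound 1 to compound 4 (1.05 log units; beyond the scatter), a large step on the core of compound 1. Set beside the earlier step on the core of compound 2, the same change did not carry over in size from one core to the other: the same change on two cores in this assay, a 1.6-fold lower number (0.20 log units; within the scatter) from compound 2 to compound 3 and an 11-fold lower number (1.05 log units; beyond the scatter) from compound 1 to compound 4, 7.0-fold (0.85 log units) apart, beyond the scatter of two such steps. This shows that, for these two pairs, the size of the step measured on one core cannot be taken as a guide to its size on the other, but it does not show which of the differences between the two cores is responsible, and two pairs give no rule for any further core in the series.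

Going by these compounds, it remains open whether the large step belongs to the bromine or to the change from benzyloxy to an aryl group on the carbonyl carbon, a question that a plain phenyl or a 4-chlorophenyl in the same place on both cores could address. On these data alone, it also remains open which part of the core of compound 1 goes with the large step, a question for a hybrid core that keeps only one of the parts in which the cores of compound 1 and compound 2 differ.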